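Cyclobutyl in place of tert-butyl: outlook for compound 4

A few compounds are considered here, and "the series" means these few. Any claim that something is new, unique, unknown or untested is made for them only; others in the source may bear on it.

Measured so far in a functional assay on HEK293 cells for activation of melanin-concentrating hormone receptor 1 (Homo sapiens), read by inositol phosphate accumulation; on this read-out lower numbers stand for an effect already at smaller amounts and higher numbers for an effect only at larger amounts of compound:
compound 1 `CCCc1cc(OC)c2cc(NC(=O)/C=C/c3ccc(C(F)(F)F)cc3)ccc2n1` gives 360 nM
compound 2 `CC(C)(C)c1cc(N)c2cc(NC(=O)/C=C/c3ccc(C(F)(F)F)cc3)ccc2n1` gives 29 nM
compound 3 `CCCc1cc(N)c2cc(NC(=O)c3ccc(-c4ccc(C(F)(F)F)cc4)cc3)ccc2n1` gives 310 nM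

Compound 2 holds the lowest number of the three; the nearest, compound 3, and the furthest, compound 1, both lie beyond the scatter from it, so compound 2 reads as the most potent measured member. Compound 4 `Nc1cc(C2CCC2)nc2ccc(NC(=O)/C=C/c3ccc(C(F)(F)F)cc3)cc12` is not yet measured. It differs from compound 2 in one place: cyclobutyl in place of tert-butyl on an aromatic carbon. Going by the values given here, no measured pair covers this exchange, and no other compound carries either group at that position, so the step cannot be read from the data. The step of a 1.6-fold higher number from compound 2 to compound 4 (0.19 log units; within the scatter) is expected to stay within the scatter, in either direction. Compound 4 is therefore estimated at 45 nM, with a range from 15 nM to 150 nM.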

Compound 4, half-maximal effective concentration: 250 nM
The estimate for compound 4 lay 5.6-fold (0.74 log units) below the measured number; measured number outside the range, above it.
By their numbers in this assay, from the lowest: compound 2; then compounds 4, 3 and 1 (each within the scatter of the next).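

At this position, on an aromatic carbon next to the ring nitrogen, cyclobutyl in place of tert-butyl gives an 8.6-fold higher number from compound 2 to compound 4 (0.94 log units; beyond the scatter) in this assay. Both groups hold 4 heavy atoms, all carbon, with no hydrogen-bond donors or acceptors, so the position responds to an exchange that leaves these counts unchanged. Nothing available bears on the reason for this step.

Open, going by these compounds, is how isopropyl or cyclopropyl at this position would read. On these data alone, with one pair covering this exchange, whether the step carries over to other compounds also stays open.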